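Ether chain extension in compound 2: cytotoxicity outlook

This account rests on a few compounds, and the source may have more. Where it says the series, first, only, none or still open, it means among the compounds named here.

Measured so far:
compound 1 `Cc1coc(-c2ccc3c(c2O)CCCC3(C)C)c1C(=O)O`: 3.3 uM
compound 2 `COCc1c(C)coc1-c1ccc2c(c1OC)CCCC2(C)C`: 19.4 uM
compound 3 `Cc1coc(-c2ccc3c(c2O)CCCC3(C)C)c1CO`: 24.5 uM

In a functional assay on A549 cells (Homo sapiens) for cytotoxicity, read by sulforhodamine B assay, with a stated time of 3 days (on this read-out lower numbers stand for an effect already at smaller amounts and higher numbers for an effect only at larger amounts of compound), compound 1 gives 3.3 uM, compound 3 gives 24.5 uM and compound 2 gives 19.4 uM. Compound 2 thus holds the second highest of the three numbers; its gap to compound 3 lies within the scatter, while its gap to compound 1 lies beyond it. Within the data shown here, the one single-place step on record, a 7.4-fold higher number from compound 1 to compound 3 (0.87 log units; beyond the scatter), concerns the group on the aromatic carbon of the shared core and leaves the ether chain untouched.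

Compound 4 `CCOCc1c(C)coc1-c1ccc2c(c1OC)CCCC2(C)C` differs from compound 2 by methyl in place of hydrogen on a saturated chain carbon bound to an oxygen on a saturated carbon, which reads, one bond further out, as methoxymethyl to ethoxymethyl. Among the measured compounds shown here, no measured pair varies that chain, so the step from compound 2 to compound 4 rests on no direct precedent. In this assay the expectation is therefore no step beyond the scatter, a 1.0-fold lower number from compound 2 to compound 4 (0.01 log units; within the scatter). For compound 4 the estimated value is 19 uM, with a range from 8 uM to 45 uM.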

Compound 4, concentration for half-maximal effect: 22.9 uM
Beside the measured number, compound 4's estimate is 1.2-fold (0.08 log units) below it; the measured number falls inside the stated range.
By their numbers in this assay, from the lowest: compound 1; then compounds 2, 4 and 3 (each within the scatter of the next).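

In this assay, among these compounds, the change from methoxymethyl to ethoxymethyl gives a 1.2-fold higher number from compound 2 to compound 4 (0.07 log units; within the scatter), the first reading on the ether chain itself. Among the compounds shown here, the only earlier step, a 7.4-fold higher number from compound 1 to compound 3 (0.87 log units; beyond the scatter), concerned hydroxymethyl in place of carboxy on an aromatic carbon and left this chain out of view, whereas methyl in place of hydrogen on the saturated chain carbon bound to the oxygen leaves the read-out within the scatter. No supporting measurement bears on this result.

Open, on these data alone, is whether the flat reading holds for a longer chain such as propoxymethyl or butoxymethyl, or for a branched isopropoxymethyl. Also open, as far as these compounds go, is how a chain ending in an amine or a carboxylic acid would read at this position, since a single step of one methyl marks no limit.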